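The compounds below may be only part of what the source reports. "The series", "measured", "known", "first", "only" and "open" are said of these compounds alone.

Measured in a functional assay on MC-38 cells (Mus musculus) for antiproliferative activity, read by colorimetric assay and MTT assay; a lower number here means a stronger inhibitor, a higher number a weaker inhibitor:
- Compound 1 `COc1ccc(S(=O)(=O)Nc2cccc3cc[nH]c23)cc1`: 1.5 ug/mL
- Compound 2 `O=S(=O)(Nc1cccc2cc[nH]c12)c1ccc(Cl)cc1`: 7 ug/mL

In this assay, compound 2 stands at 7 ug/mL, the higher of the two numbers and so the weaker of this pair. Compound 3 `O=S(=O)(Nc1cccc2c(Cl)c[nH]c12)c1ccc(Cl)cc1` has not yet been measured. It differs from compound 2 by one change: chloro in place of hydrogen on an aromatic carbon. In words, this is chloro in place of hydrogen on an aromatic carbon of the five-membered aromatic ring.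

Going by the values given here, only one measured step bears on this, and only loosely. The modest step of a 4.7-fold higher number from compound 1 to compound 2 (0.67 log units; beyond the scatter) exchanges methoxy for chloro at another place, not on the five-membered aromatic ring. Among the compounds with values here, no measured step covers the new position, so the data do not fix the direction. A change of similar modest size is expected, with a tentative lean towards a lower number and a real chance of the opposite. The estimated step is a 2.8-fold lower number from compound 2 to compound 3 (0.45 log units; beyond the scatter). For compound 3 the expected value is 2.5 ug/mL, with an estimated range of 0.5 ug/mL to 10 ug/mL.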

Compound 3, half-maximal inhibitory concentration: 0.28 ug/mL
Compound 3: the middle estimate sits 8.9-fold (0.95 log units) above what was measured; the whole stated range lies above it.
By their numbers in this assay, from the lowest: compound 3; then compound 1; then compound 2.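

In this assay, chloro in place of hydrogen on an aromatic carbon of the five-membered aromatic ring, two ring bonds from the ring nitrogen, gives a 25-fold lower number from compound 2 to compound 3 (1.40 log units; beyond the scatter), a large step beyond the scatter. Going by these compounds alone, the earlier compounds varied only another place, so this is the first sign that this position can move the number, and in the direction of a stronger inhibitor. A single added chlorine here has a larger effect than the exchange of methoxy for chloro elsewhere, which gave a 4.7-fold higher number from compound 1 to compound 2 (0.67 log units; beyond the scatter). Nothing among the data shown explains why this change has so large an effect.

The compounds shown leave open whether the step belongs to chloro itself or would also appear with another group at this carbon, such as fluoro, a methyl group, an amine or a carboxylic acid. They also leave open whether chloro at this position would have a step of similar size on the core of compound 1, which carries methoxy in place of the other chloro.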